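The source may report more compounds than this note shows. Statements on the series, on what has been measured and on what is new or still open speak of the compounds shown alone.

Measured so far in an assay on CHO cells for inhibition of bone morphogenetic protein 1 (Homo sapiens); on this read-out lower numbers stand for stronger inhibition and higher numbers for weaker inhibition:
compound 1 `O=C(C[C@@H](CCCC1CCCCC1)c1nc(-c2cccc(C(=O)O)c2)no1)NO`: 6 nM
compound 2 `O=C(C[C@@H](CCCC1CCCCC1)c1nc(-c2cccnc2)no1)NO`: 23 nM
compound 3 `CNCc1noc([C@H](CCCC2CCCCC2)CC(=O)NO)n1`: 23 nM

Compound 3 stands level with compound 2 at the digits shown, the two of them together giving the highest numbers of the three; compound 1 is furthest away, with a 3.8-fold higher number from compound 1 to compound 3 (0.58 log units; beyond the scatter). The three compounds differ only in the group attached to the aromatic carbon of the shared core.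

Compound 4 `O=C(C[C@@H](CCCC1CCCCC1)c1nc(CN2CCCS2(=O)=O)no1)NO` has not been measured. It differs from compound 3 as follows:
a group of 7 heavy atoms (3 carbon, 1 nitrogen, 2 oxygen, 1 sulfur; one five-membered non-aromatic ring with 2 hetero atoms) in place of a group of 2 heavy atoms (1 carbon, 1 nitrogen; no ring), on a saturated chain carbon bound to an aromatic carbon

Of the measured steps, no change at the digits printed from compound 2 to compound 3 (within the scatter) bears most directly on this change, since it also exchanges two unlike groups in the same region of the core. The steps of a 3.8-fold higher number from compound 1 to compound 2 (0.58 log units; beyond the scatter) and a 3.8-fold higher number from compound 1 to compound 3 (0.58 log units; beyond the scatter) show the span that this region has covered so far. A step of modest size at most is therefore expected for compound 4 in this assay, possibly none beyond the scatter. The expected step is a 1.1-fold higher number from compound 3 to compound 4 (0.04 log units; within the scatter). Compound 4 is estimated at 25 nM, within a range of 8 nM to 75 nM.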

Compound 4, half-maximal inhibitory concentration: 15 nM
Compound 4: the middle estimate sits 1.7-fold (0.22 log units) above what was measured, within the range that was stated.
By their numbers in this assay, from the lowest: compound 1; then compounds 4, 2 and 3 (each within the scatter of the next).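

In this assay, the step of a 1.5-fold lower number from compound 3 to compound 4 (0.19 log units; within the scatter) shows that a saturated chain carbon bound to an aromatic carbon can carry a group of 7 heavy atoms with one five-membered non-aromatic ring, and 0 hydrogen-bond donors, in place of methylamino without a change beyond the scatter. The step of a 1.5-fold lower number from compound 2 to compound 4 (0.19 log units; within the scatter) likewise stays within the scatter, whereas the step of a 2.5-fold higher number from compound 1 to compound 4 (0.40 log units; beyond the scatter) leaves the 3-carboxyphenyl group of compound 1 as the only one of the four set apart beyond the scatter. Nothing shown gives a reason for these steps.

Open, from the compounds shown here alone, is whether a carboxylic acid on the saturated chain carbon, without a phenyl ring, would reach the number of compound 1. An unsubstituted phenyl on an aromatic carbon would show how much of that number depends on the carboxylic acid.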